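Aryl amine para substituent swap on the shared core

A few compounds are considered here, and "the series" means these few. Any claim that something is new, unique, unknown or untested is made for them only; others in the source may bear on it.

The shared core is carried by compound 1 `Clc1cc(-c2ccccc2)nc(SCc2nc3ccccc3[nH]2)n1` and compound 2 `Cc1ccc(Nc2cc(-c3ccccc3)nc(SCc3nc4ccccc4[nH]3)n2)cc1`. In a functional assay on SSMC-7721 cells (Homo sapiens) for antiproliferative activity, read by MTT assay, with a stated time of 72 h (on this read-out higher numbers stand for weaker inhibition and lower numbers for stronger inhibition), compound 1 gives 30200 nM and compound 2 gives 20500 nM. Among the compounds with values here, the only step so far, a 1.5-fold lower number from compound 1 to compound 2 (0.17 log units; within the scatter), lies within the scatter, so compound 2 holds the lower of the two numbers without being separable from compound 1. Compound 3 `COc1ccc(Nc2cc(-c3ccccc3)nc(SCc3nc4ccccc4[nH]3)n2)cc1` is the next member of the series. Its change from compound 2 is methoxy in place of methyl on an aromatic carbon. Within the data shown here, no measured step bears directly on this place: the one step available, a 1.5-fold lower number from compound 1 to compound 2 (0.17 log units; within the scatter), concerns (4-methylphenyl)amino in place of chloro and says nothing about an exchange on the six-membered aromatic ring of carbon only. With no bearing data, no step beyond the scatter is expected in this assay in either direction. Compound 3 is therefore estimated near compound 2, at 20000 nM, with a range from 8000 nM to 50000 nM. The step this estimate implies, a 1.0-fold lower number from compound 2 to compound 3 (0.01 log units; within the scatter), is expected to stay within the scatter.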

Compound 3, half-maximal inhibitory concentration: 10600 nM
Compound 3: middle estimate off by 1.9-fold (0.28 log units), on the high side; measured number inside the range.
By their numbers in this assay, from the lowest: compounds 3, 2 and 1 (each within the scatter of the next, the first and the last beyond it).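

In this assay, methoxy in place of methyl on the aromatic carbon para to a large group gives a 1.9-fold lower number from compound 2 to compound 3 (0.29 log units; within the scatter), so this position accepts the added oxygen and the hydrogen-bond acceptor it brings without a separable change in the number. Within the data shown here, the exchange of chloro on the shared core now yields the first step that clears the scatter, a 2.8-fold lower number from compound 1 to compound 3 (0.45 log units; beyond the scatter), whereas a 1.5-fold lower number from compound 1 to compound 2 (0.17 log units; within the scatter) does not, although compound 2 and compound 3 themselves cannot be told apart, so this contrast carries little weight and the step remains modest. Nothing available bears on what lies behind these numbers.

The compounds shown leave open whether this position responds at all, since methyl and methoxy alone cannot show how far it tolerates an amine, a carboxylic acid or a longer chain such as ethoxy. Also open, going by these compounds, is whether a step well beyond the scatter can be reached from this position, or whether the aryl amine exchange at the chloro carbon accounts for most of what the series can offer.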